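A few compounds are considered here, and "the series" means these few. Any claim that something is new, unique, unknown or untested is made for them only; others in the source may bear on it.

Compound 2 `O=[N+]([O-])c1cc(CNCCCNC2CCCCC2)ccc1CNCCCNC1CCCCC1` — 354 nM
Compound 1 `O=C(NCCCNC1CCCCC1)c1ccc(CNCCCNC2CCCCC2)cc1` — 699 nM

Of the compounds shown here, two have so far been measured in an assay on CHO cells for displacement of a labelled ligand from C-X-C chemokine receptor type 4 (Homo sapiens), with a stated time of 40 min; a higher number here means a weaker inhibitor, a lower number a stronger inhibitor. Both carry the same two side chains on a shared core. Compound 2 gives the lower of the two numbers, 354 nM in this assay, while compound 1 gives 699 nM. The gap between them lies within the usual scatter of repeated measurements, so on this evidence the two cannot be told apart, and neither can be called the more potent.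

Compound 3 `Nc1cc(CNCCCNC2CCCCC2)ccc1CNCCCNC1CCCCC1` has not yet been measured. It differs from compound 2 in one place: amino in place of nitro on an aromatic carbon. For the measured compounds named here, no measured pair in this set shows what such an exchange does in this assay, so the size and direction of the step rest on no direct precedent. With nothing in the data pointing either way, the expected step is a 1.1-fold higher number from compound 2 to compound 3 (0.05 log units; within the scatter), that is, no change beyond the scatter. Compound 3 is therefore estimated to give about 400 nM in this assay, with a likely range from 150 nM to 1200 nM.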

Compound 3, half-maximal inhibitory concentration: 68.9 nM
Estimate against measurement, compound 3: 5.8-fold (0.76 log units) above; the whole stated range lies above it.
By their numbers in this assay, from the lowest: compound 3; then compounds 2 and 1 (each within the scatter of the next).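

For the compounds shown here, compound 3 gives the first step in this set between compounds that differ in one place. On this aromatic carbon, ortho to a large group and meta to a large group, amino in place of nitro brings a 5.1-fold lower number from compound 2 to compound 3 (0.71 log units; beyond the scatter) in this assay, which shows that the group at this position can shift the result beyond the scatter. This single exchange alters the heavy-atom count and the numbers of hydrogen-bond donors and acceptors all at once, so the pair cannot show which of these differences matters, and no measurement shown here accounts for the size of the step.

On these data alone, it remains open whether the lower number belongs to amino specifically or would also appear with a plain hydrogen, a hydroxyl or a methyl group on the same carbon. As far as these compounds go, it is equally open whether an amine carrying a substituent, such as dimethylamino or an acetamide, would keep the number seen for compound 3, or whether the same exchange would give a similar step with a longer chain in the two side chains.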